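Ethyl to Isopropyl on the Urea Nitrogen

This account rests on a few compounds, and the source may have more. Where it says the series, first, only, none or still open, it means among the compounds named here.

In a functional assay on MCF7 cells (Homo sapiens) for cytotoxicity, read by MTT assay, with a stated time of 72 h (a lower number here means a stronger inhibitor, a higher number a weaker inhibitor), compound 2 `CCNC(=O)N1CCN(C(=S)SCc2cn(Cc3ccc(Cl)cc3)nn2)CC1` gives > 128000 nM, a limit of the assay rather than a number. Compound 2 therefore stands at the limit of > 128000 nM in this assay, at which 1 of the 2 values shown sits. Compound 1 `CC(C)NC(=O)N1CCN(C(=S)SCc2cn(Cc3ccc(F)cc3)nn2)CC1` differs from compound 2 in two places; in this assay compound 1 gives 1660 nM. Compound 3 `CC(C)NC(=O)N1CCN(C(=S)SCc2cn(Cc3ccc(Cl)cc3)nn2)CC1` is separated from compound 2 by methyl in place of hydrogen on a saturated chain carbon bound to an amide-type nitrogen and a saturated chain carbon. Among the compounds with values here, no measured pair isolates this change, so its size is not known from the data. The expected step is an at least 21-fold lower number from compound 2 to compound 3 (1.32 log units; beyond the scatter), toward stronger inhibition, since compound 1 shows an isopropyl analog can be active. Compound 3 is expected near 6000 nM, within 1200 nM to 100000 nM.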

Compound 3, half-maximal inhibitory concentration: > 128000 nM
Compound 3: no number, only a limit; the forecaster's own chance of this, stated with the estimate: 30%; middle value at least 21-fold (1.32 log units) away from the limit.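

In this assay, isopropyl on the urea nitrogen does not by itself give a measurable value: compound 3 gives > 128000 nM, a limit of the assay. Within the data shown here, with isopropyl held fixed, chloro in place of fluoro on an aromatic carbon brings an at least 77-fold higher number from compound 1 to compound 3 (1.88 log units; beyond the scatter), so the halogen is the one change here whose effect can be read. The step from ethyl to isopropyl cannot be read, as compound 3 joins compound 2 at one shared limit: the limit of > 128000 nM in this assay, at which 2 of the 3 values shown sit.

Open, from the compounds shown here alone, is whether ethyl on the urea nitrogen would also give a number when paired with fluoro. Also open, going by these compounds, is whether hydrogen, methoxy or a nitrile in place of the halogen would do the same.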